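A few compounds are considered here, and "the series" means these few. Any claim that something is new, unique, unknown or untested is made for them only; others in the source may bear on it.

In a functional assay on the whole organism for inhibition, with Cavia porcellus as the target, with a stated time of 2 h (on this read-out lower numbers stand for an effect already at smaller amounts and higher numbers for an effect only at larger amounts of compound), compound 2 (`CCCCCCCC/C(=C\C=C\C(=O)N[C@H](C)CCCc1cccnc1)c1ccc(OC)cc1`) gives 13 mg/kg. Compound 1 (`CCCC/C(=C\C=C\C(=O)N[C@H](C)CCCc1cccnc1)c1ccc(OC)cc1`) gives 12 mg/kg, which is within the scatter of compound 2, so the two stand level. Compound 3 (`COc1ccc(C(=C/C=C/C(=O)Nc2ccc(-c3cccnc3)cc2)c2ccc(OC)cc2)cc1`), with a different core and no such alkyl chain, gives 29 mg/kg, a higher number than compound 2 and beyond the scatter.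

The next compound is compound 4 (`CC/C(=C\C=C\C(=O)N[C@H](C)CCCc1cccnc1)c1ccc(OC)cc1`). The change from compound 2 is hydrogen in place of hexyl on a saturated chain carbon, two bonds along the chain from a double-bonded chain carbon, in words hydrogen in place of hexyl on a saturated chain carbon, two bonds along the chain from a double-bonded chain carbon. The same difference, cut one bond further out, reads octyl to ethyl.

Going by the values given here, only one measured step bears on this chain: a 1.1-fold higher number from compound 1 to compound 2 (0.03 log units; within the scatter). That step lies within the scatter, so lengthening the chain by butyl left this assay without a visible change. Compound 4 nevertheless falls outside the chain lengths measured so far, and a single flat step cannot show what happens there, so the range is kept wide. The expectation is no step beyond the scatter, with an estimated 1.1-fold higher number from compound 2 to compound 4 (0.03 log units; within the scatter).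

For compound 4 the estimated dose is 14 mg/kg, with an expected range of 6 mg/kg to 30 mg/kg.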

Compound 4, dose for 50% inhibition: 35 mg/kg
Beside the measured number, compound 4's estimate is 2.5-fold (0.40 log units) below it; measured number outside the range, above it.
By their numbers in this assay, from the lowest: compounds 1 and 2 (each within the scatter of the next); then compounds 3 and 4 (each within the scatter of the next).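

Shortening the chain at this carbon does register in this assay: hydrogen in place of hexyl, which reads octyl to ethyl, gives a 2.7-fold higher number from compound 2 to compound 4 (0.43 log units; beyond the scatter), and hydrogen in place of ethyl at the same place gives a 2.9-fold higher number from compound 1 to compound 4 (0.46 log units; beyond the scatter). The earlier pair reads flat, with a 1.1-fold higher number from compound 1 to compound 2 (0.03 log units; within the scatter) as its step. Compound 4, with its ethyl chain, does not stand level with that pair; among compounds 1, 2 and 4, only the shortest chain stands apart, and both steps to it are modest. No measurement on hand accounts for this change.

The compounds shown leave open how the number moves with chain length below that of compound 1, a point that a propyl chain at this place would address, and whether a methyl chain would take the series further in the same direction. Also open, from the compounds shown here alone, are whether a chain longer than octyl would stay level with compound 2, and how a chain ending in an amine or a carboxylic acid would read out.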